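This account rests on a few compounds, and the source may have more. Where it says the series, first, only, none or still open, it means among the compounds named here.

Going by the values given here, compound 2 `Nc1nn(C(=O)Nc2ccc(Cc3ccccc3)cc2)c2ccc(Cl)cc12` holds the only plain number in the set: in a functional assay on SNB-19 cells (Homo sapiens) for antiproliferative activity, read by sulforhodamine B assay, with a stated time of 48 h (a lower number here means a stronger inhibitor of growth, a higher number a weaker inhibitor of growth), compound 2 gives 43300 nM. Compound 1 `Nc1nn(C(=O)Nc2ccc(Cc3ccccc3)cc2)c2ccccc12` differs from it by chloro in place of hydrogen on an aromatic carbon; in this assay compound 1 gives > 100000 nM, which is a limit of the assay and not a number. Among the compounds with values here, the single measured step, an at least 2.3-fold lower number from compound 1 to compound 2 (0.36 log units; beyond the scatter), therefore rests on the limit of > 100000 nM in this assay, at which 1 of the 2 values shown sits, and fixes only a floor for its size.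

Compound 3 `Nc1ccc2c(c1)c(N)nn2C(=O)Nc1ccc(Cc2ccccc2)cc1` carries amino in place of chloro on an aromatic carbon. Within the data shown here, no measured step covers an amino group at this position; the only guidance is that removing the chloro returned compound 1 to the limit, so the chloro counts for something. With the chloro gone again and amino in its place, the number is expected to drift back toward the weaker side. A modest rise in the number is expected, a 1.8-fold higher number from compound 2 to compound 3 (0.27 log units; within the scatter). For compound 3 the estimated value in this assay is 80000 nM, within 25000 nM to 250000 nM.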

Compound 3, concentration for total growth inhibition: 27300 nM
Compound 3: the middle estimate sits 2.9-fold (0.47 log units) above what was measured, within the range that was stated.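

In this assay, amino in place of chloro gives a 1.6-fold lower number from compound 2 to compound 3 (0.20 log units; within the scatter), so the two groups cannot be told apart at this position, although amino adds a hydrogen-bond donor and a hydrogen-bond acceptor that chloro lacks. Measured against hydrogen, amino gives an at least 3.6-fold lower number from compound 1 to compound 3 (0.56 log units; beyond the scatter), so a second group at this position now goes the same way as chloro, and the earlier step no longer stands alone. For compound 1 the value is a limit of the assay and not a number, so this step too fixes only a floor for its size: the limit of > 100000 nM in this assay, at which 1 of the 3 values shown sits.

From the compounds shown here alone, whether any group at this position would do the same stays open, since a methoxy group or a carboxylic acid here would test that reading. Going by these compounds, the three compounds also share the rest of the core unchanged, so what other parts of it contribute remains unknown.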